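Adding Chloro to the Core of Compound 1

This account rests on a few compounds, and the source may have more. Where it says the series, first, only, none or still open, it means among the compounds named here.

Compound 1 `Nc1nc(-c2ccccc2)nn1-c1ncnc2ccccc12`: 1000 nM
Compound 2 `COc1ccc(-c2nc(N)n(-c3ncnc4ccccc34)n2)cc1`: 5000 nM

Among the compounds with values here, in a physicochemical assay for solubility, in phosphate buffer, with a stated time of 18 h, at pH 7.4 (a lower number here means a less soluble compound, a higher number a more soluble compound), compound 1 gives 1000 nM, the lower of the two numbers so far, and compound 2 gives 5000 nM. Within the data shown here, the only measured step is a 5.0-fold higher number from compound 1 to compound 2 (0.70 log units; beyond the scatter), which puts methoxy in place of hydrogen on an aromatic carbon.

Compound 3 `Nc1nc(-c2ccccc2)nn1-c1ncnc2cc(Cl)ccc12` has not yet been measured in this assay. It differs from compound 1 by chloro in place of hydrogen on an aromatic carbon. In words, this is chloro in place of hydrogen on an aromatic carbon of a six-membered aromatic ring of carbon only, part of a fused or bridged system of two rings.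

Among the measured compounds shown here, the methoxy step bears on this change only loosely, as no measured compound carries chloro. Its modest size suggests a change of similar or smaller size, but it does not settle the direction. A small drop is the tentative expectation, one that the data cannot yet test. The step expected here is a 1.4-fold lower number from compound 1 to compound 3 (0.15 log units; within the scatter). For compound 3 the expected value is 700 nM, with an estimated range from 250 nM to 2000 nM.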

Compound 3, solubility: 300 nM
Estimate against measurement, compound 3: 2.3-fold (0.37 log units) above; measured number inside the range.
By their numbers in this assay, from the lowest: compound 3; then compound 1; then compound 2.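

In this assay the chloro change gives a 3.3-fold lower number from compound 1 to compound 3 (0.52 log units; beyond the scatter) and so now has a measured direction, on an aromatic carbon of a six-membered aromatic ring of carbon only, part of a fused or bridged system of two rings. Within the data shown here, this is the first measured change at this place on the shared core, as compound 2 carries its methoxy elsewhere. With a 5.0-fold higher number from compound 1 to compound 2 (0.70 log units; beyond the scatter) set against it, the two single steps from compound 1 run in opposite directions, each beyond the scatter, so among these compounds no one direction holds for replacing hydrogen on an aromatic carbon.

No measurement at hand offers an explanation for the chloro step. As far as these compounds go, whether an amine or a carboxylic acid at this same place would lower the number as chloro does stays open, as does whether chloro would give a step of similar size elsewhere on the core of compound 1.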